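Replacing the pentenyl chain of compound 3

The source may hold more compounds than are shown below. What is called first, only, known or untested is meant among the compounds shown, and "the series" means these compounds.

compound 1 `COc1cccc(Nc2nc3c(c(Oc4cccc(NC(=O)C=C(C)C)c4)n2)CSCC3)c1`: > 50000 nM (a limit)
compound 2 `C/C=C/C(=O)Nc1cccc(Oc2nc(Nc3cccc(C#N)c3)nc3c2CSCC3)c1`: 21400 nM
compound 3 `CCC/C=C/C(=O)Nc1cccc(Oc2nc(Nc3cccc(C#N)c3)nc3c2CSCC3)c1`: 15300 nM

In a functional assay on MCF7 cells (Homo sapiens) for antiproliferative activity, read by MTT assay, with a stated time of 72 h (on this read-out higher numbers stand for weaker inhibition and lower numbers for stronger inhibition), compound 3 gives 15300 nM and stands level with compound 2, at 21400 nM, as the two values lie within the scatter of each other. Compound 1, which carries 2-methylprop-1-en-1-yl on a carbonyl carbon, gives > 50000 nM, and this is a limit of the assay, not a number.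

Compound 4 `CC(C)=CC(=O)Nc1cccc(Oc2nc(Nc3cccc(C#N)c3)nc3c2CSCC3)c1` differs from compound 3 in one place: 2-methylprop-1-en-1-yl in place of pent-1-en-1-yl on a carbonyl carbon. The 2-methylprop-1-en-1-yl group thus stands in place of pent-1-en-1-yl on a carbonyl carbon. Within the data shown here, the one measured step on this chain is a 1.4-fold lower number from compound 2 to compound 3 (0.15 log units; within the scatter), so no step beyond the scatter is expected in this assay for the new change. Among the measured compounds shown here, no measured step joins compound 1 to the others. The expected change is a 1.4-fold higher number from compound 3 to compound 4 (0.16 log units; within the scatter). For compound 4 the estimated value is 22000 nM, with an expected range from 10000 nM to 50000 nM.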

Compound 4, half-maximal inhibitory concentration: > 50000 nM
Compound 4 ended at the assay's limit; the forecaster's own chance of this, stated with the estimate: 15%; middle value at least 2.2-fold (0.35 log units) from the limit.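

In this assay, the group on the carbonyl carbon now matters beyond the scatter: 2-methylprop-1-en-1-yl in place of pent-1-en-1-yl gives an at least 3.2-fold higher number from compound 3 to compound 4 (0.51 log units; beyond the scatter), and 2-methylprop-1-en-1-yl in place of prop-1-en-1-yl gives an at least 2.3-fold higher number from compound 2 to compound 4 (0.36 log units; beyond the scatter). Among these compounds, the only earlier step on this position, between the two straight chains, stayed within the scatter, with a 1.4-fold lower number from compound 2 to compound 3 (0.15 log units; within the scatter). For compound 4, > 50000 nM is a limit of the assay and not a number: the limit of > 50000 nM in this assay, at which 2 of the 4 values shown sit.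

The step between compound 1 and compound 4, which would show the effect of cyano in place of methoxy on an aromatic carbon, cannot be read. On these data alone, whether an amine or a carboxylic acid on the chain, or a chain longer than pent-1-en-1-yl, would change the number in this assay stays open.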